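Aryl change on the five-membered ring nitrogen

The source may hold more compounds than are shown below. What is called first, only, known or untested is meant among the compounds shown, and "the series" means these compounds.

Compound 2 `COc1cc2c(Oc3ccc(NC(=O)c4cn(-c5ccccc5)nn4)cc3F)ccnc2cc1OCCCN1CCC(C)CC1` and compound 1 `COc1cc2c(Oc3ccc(NC(=O)c4cn(-c5ccccc5)nn4)cc3F)ccnc2cc1OCCCN1CCCC1` share one core and differ only in the amine at the end of the saturated chain. Among the compounds with values here, in a functional assay on MKN-45 cells (Homo sapiens) for cytotoxicity, read by MTT assay, with a stated time of 72 h (on this read-out higher numbers stand for weaker inhibition and lower numbers for stronger inhibition), compound 1 gives 260 nM and compound 2 gives 90 nM; the step of a 2.9-fold lower number from compound 1 to compound 2 (0.46 log units; beyond the scatter) is the only measured step, and compound 2 holds the lowest of the two numbers. Compound 3 `COc1cc2c(Oc3ccc(NC(=O)c4cn(-c5c(Cl)cccc5Cl)nn4)cc3F)ccnc2cc1OCCCN1CCC(C)CC1` keeps the amine of compound 2 and carries the change (2,6-dichlorophenyl in place of phenyl on an aromatic nitrogen). Within the data shown here, no measured step touches this part of the molecule; the one step measured concerns the saturated chain and does not bear on it. With nothing measured at this site, the expected step of no change at the digits printed from compound 2 to compound 3 (within the scatter) is none beyond the scatter, with a wide allowance either way. Compound 3 is estimated at 90 nM in this assay, with a range of 30 nM to 300 nM.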

Compound 3, half-maximal inhibitory concentration: 120 nM
For compound 3 the middle estimate is 1.3-fold (0.12 log units) below the measured one; low and high end bracket the measured number.
By their numbers in this assay, from the lowest: compounds 2 and 3 (each within the scatter of the next); then compound 1.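

Working notes on the aryl group on the aromatic nitrogen: the first measured step at this position, 2,6-dichlorophenyl in place of phenyl, reads a 1.3-fold higher number from compound 2 to compound 3 (0.12 log units; within the scatter) in this assay and so does not separate the two aryl groups. Within the data shown here, the position therefore accepts 2,6-dichlorophenyl with no step beyond the scatter, while the only step beyond the scatter remains a 2.9-fold lower number from compound 1 to compound 2 (0.46 log units; beyond the scatter) at the amine on the saturated chain. Nothing measured on these compounds offers an explanation for this result.

Going by these compounds, whether a single chlorine on the phenyl, or a methoxy group or pyridyl ring at this site, would give a step beyond the scatter stays open. Also open, on these data alone, is whether 2,6-dichlorophenyl reads the same with the pyrrolidin-1-yl amine of compound 1 at the chain end.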